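A few compounds are considered here, and "the series" means these few. Any claim that something is new, unique, unknown or untested is made for them only; others in the source may bear on it.

In a functional assay on MOLT-4 cells (Homo sapiens) for inhibition (a higher number here means a weaker inhibitor, a lower number a stronger inhibitor), compound 3 `O=C1/C(=C/c2ccc(F)cc2)CCCc2ccccc21` gives 53600 nM. Compound 1 `O=C1/C(=C/c2ccc(F)cc2)Cc2ccccc21` gives 60000 nM, and these two numbers lie within the usual scatter of each other, so neither can be ranked ahead of the other. Compound 2 `O=C1/C(=C/c2ccc(Br)cc2)CCc2ccccc21` is reported only as a limit, > 500000 nM, and this is not a measured number.

The next compound, compound 4 `CN(C)c1ccc(/C=C2\CCCc3ccccc3C2=O)cc1`, keeps the core of compound 3 and changes a single group: dimethylamino in place of fluoro on an aromatic carbon. In words, dimethylamino stands in place of fluoro on an aromatic carbon, para to a large group.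

For the measured compounds named here, no two measured compounds differ in just one place, which leaves no measured step to show what such a swap does in this assay. With nothing to point in either direction, no change beyond the scatter is expected, and the best anchor is compound 3 at 53600 nM. The expected change is small, as a 1.2-fold lower number from compound 3 to compound 4 (0.08 log units; within the scatter) shows. The uncertainty stays wide, especially towards weaker inhibition, given that one of the three measured compounds gave no number at all. For compound 4, the estimated value is 45000 nM, with an expected range from 12000 nM to 170000 nM.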

Compound 4, half-maximal inhibitory concentration: 5250 nM
The estimate for compound 4 lay 8.6-fold (0.93 log units) above the measured number; measured number below the stated range.
By their numbers in this assay, from the lowest: compound 4; then compounds 3 and 1 (each within the scatter of the next). At a limit, above all of these: compound 2.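

In this assay, dimethylamino in place of fluoro on an aromatic carbon, para to a large group, gives a 10-fold lower number from compound 3 to compound 4 (1.01 log units; beyond the scatter). For the compounds shown here, this is the first step between two compounds that differ in one place only, and it shows that this position is far from silent: on the core of compound 3, the group held there can move the number a long way, here towards stronger inhibition, with compound 4 at 5250 nM. No measurement shown here bears on why the step is so large.

On these data alone, it remains open whether this gain belongs to dimethylamino itself, or whether a smaller amine, a methoxy group or a carboxylic acid at the same place would lower the number as well, leave it unchanged or raise it. Also open, as far as these compounds go, is whether the same swap would do as much on the core of compound 1, which carries fluoro at this place too, since one pair of compounds cannot show whether a step carries over from one core to another.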